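A furan for a chlorothiophene on the shared bicyclic amine core

The source may hold more compounds than are shown below. What is called first, only, known or untested is meant among the compounds shown, and "the series" means these compounds.

Compound 2 `C[C@H]1[C@H](NCc2ccc(Cl)s2)C[C@H]2C[C@@H]1C2(C)C` was examined in an ADME assay on MDCK cells (Canis lupus familiaris) for cytotoxicity, read by microscopy, with a stated time of 48 h (a higher number here means that more compound is tolerated, a lower number that less compound is tolerated), where compound 2 gives 25000 nM. Of the three compounds measured, compound 2 and compound 3 `CCCCc1ccsc1CN[C@@H]1C[C@H]2C[C@@H]([C@H]1C)C2(C)C` stand together at the top, since compound 3 gives 25000 nM and the two numbers do not differ at the digits shown. Compound 1 `CCc1ccc(CN[C@@H]2C[C@H]3C[C@@H]([C@H]2C)C3(C)C)s1` lies furthest away, as compound 1 gives 1560 nM, and the step of a 16-fold higher number from compound 1 to compound 2 (1.20 log units; beyond the scatter) is a large one.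

Compound 4 `C[C@H]1[C@H](NCc2ccco2)C[C@H]2C[C@@H]1C2(C)C` has not been measured. It differs from compound 2 in one place: furan-2-yl in place of 5-chlorothiophen-2-yl on a saturated chain carbon bound to an amine nitrogen. Among the measured compounds shown here, no measured step touches this exchange of one heteroaromatic ring for another. For the measured compounds named here, the only step recorded, from compound 1 to compound 2, concerns a chloro in place of an ethyl on the thiophene and was large, which shows that substituents on this ring can move the number considerably in this assay; it gives no direct guide for removing the chlorine and changing the ring atom at once. The shift is therefore expected to be modest and downward, within a 2.1-fold lower number from compound 2 to compound 4 (0.32 log units; beyond the scatter). For compound 4 the value in this assay is estimated at 12000 nM, with a range from 3000 nM to 25000 nM.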

Compound 4, minimum cytotoxic concentration: 50000 nM
Compound 4: the middle estimate sits 4.2-fold (0.62 log units) below what was measured; the whole stated range lies below it.
By their numbers in this assay, from the lowest: compound 1; then compounds 2, 3 and 4 (each within the scatter of the next).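

In this assay, the exchange at this place, on a saturated chain carbon bound to an amine nitrogen, gives a 2.0-fold higher number from compound 2 to compound 4 (0.30 log units; within the scatter), so the 5-chlorothiophen-2-yl group of compound 2 can give way to furan-2-yl without a shift that stands clear of repeated measurements. The earlier compounds shown here showed only that replacing one substituent on the thiophene, with chloro in place of ethyl, can move the number by a large step; this pair adds that the ring sulfur and the chlorine can leave together, along with one heavy atom overall, while the reading stays within the scatter, and it extends the tolerated set on the shared core to a second heteroaromatic ring. No measurement available here accounts for this outcome.

Since the sulfur and the chlorine leave in a single step, the compounds shown cannot tell what each contributes alone, and a plain thiophene ring carrying no chlorine or a furan ring carrying a chloro or an ethyl group would separate the two. From the compounds shown here alone, it also remains open whether a six-membered ring such as phenyl or pyridine would fit the same pattern at this place.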